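This account rests on a few compounds, and the source may have more. Where it says the series, first, only, none or still open, it means among the compounds named here.

In a physicochemical assay for lipophilicity, at pH 7.4 (on this read-out lower numbers stand for lower lipophilicity and higher numbers for higher lipophilicity), compound 1 `Cc1cc(/C=C/C#N)cc(C)c1Oc1cc(Nc2ccc(C#N)cc2)c(N)cc1C(N)=O` gives 3.53. Compound 2 `Cc1cc(/C=C/C#N)cc(C)c1Oc1cc(Nc2ccc(C#N)cc2)c(N)cc1[N+](=O)[O-]` gives > 5, which is a limit and not a number. Compound 3 `Cc1cc(/C=C/C#N)cc(C)c1Oc1cc(Nc2ccc(C#N)cc2)c(N)cc1C(F)(F)F` gives > 5, also a limit. Compound 3 thus stands at the limit of > 5 in this assay, at which 2 of the 3 values shown sit.

Compound 4 `CNC(=O)c1cc(N)c(Nc2ccc(C#N)cc2)cc1Oc1c(C)cc(/C=C/C#N)cc1C` carries methylcarbamoyl in place of trifluoromethyl on an aromatic carbon. The closest measured change is the reverse exchange, trifluoromethyl in place of carbamoyl, which gave a number at least 1.47 log units higher from compound 1 to compound 3 (beyond the scatter). Nitro in place of carbamoyl gave a number at least 1.47 log units higher from compound 1 to compound 2 (beyond the scatter).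

A large step down is therefore expected in this assay, back towards compound 1 at 3.53. The expected change is a number at least 1.20 log units lower from compound 3 to compound 4 (beyond the scatter). For compound 4 the estimate is 3.8, with an expected range of 3.3 to 4.4.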

Compound 4, partition coefficient: 4.12
The estimate for compound 4 lay 0.32 log units below the measured number; the range from low to high includes it.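

In this assay methylcarbamoyl on this aromatic carbon gives a number at least 0.88 log units lower from compound 3 to compound 4 (beyond the scatter) and also a number at least 0.88 log units lower from compound 2 to compound 4 (beyond the scatter) when the comparison is made with nitro. Methyl in place of hydrogen on the amide-type nitrogen gives a number 0.59 log units higher from compound 1 to compound 4 (beyond the scatter) and shows that the read-out responds to substitution on the amide nitrogen itself, not only to exchange of the whole group. Compound 2 and compound 3 are each given only as a limit and not as a number: the limit of > 5 in this assay, at which 2 of the 4 values shown sit.

The step between compound 2 and compound 3 cannot be read. On these data alone, whether an ethyl or longer chain on the amide nitrogen extends the rise seen with methyl, or how a carboxylic acid at this position would read, remains open.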